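Amide Swap on a Weakly Active Pyrrolopyrimidine Pair

The source may hold more compounds than are shown below. What is called first, only, known or untested is meant among the compounds shown, and "the series" means these compounds.

Two compounds measured in a functional assay on MIA PaCa-2 cells (Homo sapiens) for inhibition, read by MTT assay (a lower number here means a stronger inhibitor, a higher number a weaker inhibitor), set the stage. Compound 1 `CN(C)C(=O)c1cc2cnc(Nc3ccc(Cl)cc3)nc2n1C1CCCC1` is the better of the two: in this assay compound 1 gives 13000 nM. Compound 2 `O=C(c1cc2cnc(Nc3ccc(N4CCNCC4)cn3)nc2n1C1CCCC1)N1CCCCC1` stands with the highest number of the pair; in this assay compound 2 gives 39600 nM, a gap to compound 1 that lies beyond the usual scatter.

Compound 3 `O=C(Nc1ccccc1F)c1cc2cnc(Nc3ccc(N4CCNCC4)cn3)nc2n1C1CCCC1` keeps the whole of compound 2 except the amide, where the change is (2-fluorophenyl)amino in place of piperidin-1-yl on a carbonyl carbon. Going by the values given here, no pair measured here isolates this change, so its effect is unknown. Given how weak compound 2 is in this assay at 39600 nM, a modest move toward stronger inhibition is expected, though one that may not clear the scatter, so the step from compound 2 to compound 3 is expected to be a 2.0-fold lower number from compound 2 to compound 3 (0.30 log units; within the scatter). Compound 3 is therefore estimated at 20000 nM in this assay, with a range from 5000 nM to 80000 nM.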

Compound 3, half-maximal inhibitory concentration: 3670 nM
The estimate for compound 3 lay 5.4-fold (0.74 log units) above the measured number; the whole stated range lies above it.
By their numbers in this assay, from the lowest: compound 3; then compound 1; then compound 2.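

In this assay, going by these compounds alone, the group on this carbonyl carbon proves able to move the read-out strongly: putting (2-fluorophenyl)amino in place of piperidin-1-yl gives an 11-fold lower number from compound 2 to compound 3 (1.03 log units; beyond the scatter) and is the first single-place change measured here. The swap brings in a six-membered aromatic ring of carbon only, a fluorine and a hydrogen-bond donor together, so this one pair cannot assign the step to any of them. Nothing measured here explains why the number falls.

From the compounds shown here alone, how the step divides among the fluorine, the aromatic ring and the amide hydrogen remains open. A plain phenylamino group or a cyclohexylamino group on the same carbonyl carbon would bear on that question, as would a methylamino group for the amide hydrogen alone.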